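Adding bromo to the chain of compound 2

This account rests on a few compounds, and the source may have more. Where it says the series, first, only, none or still open, it means among the compounds named here.

Measured so far in a functional assay on HCT-116 cells (Homo sapiens) for inhibition, read by MTT assay, with a stated time of 48 h; a higher number here means a weaker inhibitor, a lower number a stronger inhibitor
Compound 1 `CC/C=C/C(=O)N(Cc1ccc(OC)c(O)c1)c1cc(OC)c(OC)c(OC)c1` gives 63 nM
Compound 2 `C/C=C/C(=O)N(Cc1ccc(OC)c(O)c1)c1cc(OC)c(OC)c(OC)c1` gives 55 nM

For the measured compounds named here, at 55 nM compound 2 stands within the scatter of compound 1, its only measured neighbour. The next structure is compound 3 `COc1ccc(CN(C(=O)/C=C/CBr)c2cc(OC)c(OC)c(OC)c2)cc1O` and the change is bromo in place of hydrogen on a saturated chain carbon bound to a double-bonded chain carbon, which amounts to methyl to bromomethyl. Going by the values given here, one measured step bears on this place: a 1.1-fold lower number from compound 1 to compound 2 (0.06 log units; within the scatter), with hydrogen in place of methyl. That step lay within the scatter, but it involves no bromo group, so it is only a weak guide. No step beyond the scatter is therefore expected in this assay, and neither direction is favoured. The expected step is a 1.1-fold lower number from compound 2 to compound 3 (0.04 log units; within the scatter) and it carries wide uncertainty. For compound 3 the estimated value is 50 nM with an expected range of 15 nM to 170 nM in this measurement.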

Compound 3, half-maximal inhibitory concentration: 59 nM
Compound 3: middle estimate off by 1.2-fold (0.07 log units), on the low side; measured number inside the range.
By their numbers in this assay, from the lowest: compounds 2, 3 and 1 (each within the scatter of the next).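

Bromo in place of hydrogen on a saturated chain carbon bound to a double-bonded chain carbon gives a 1.1-fold higher number from compound 2 to compound 3 (0.03 log units; within the scatter) in this assay, and bromo in place of methyl on that carbon gives a 1.1-fold lower number from compound 1 to compound 3 (0.03 log units; within the scatter). For the compounds shown here, until now this place had been seen only with hydrogen and methyl; a bromo group now joins them, and all three compounds stand within the scatter of one another. The compounds shown therefore extend the flat picture at this place to a halogen, although nothing given here accounts for it.

Going by these compounds alone, with every step so far within the scatter, it remains open whether any group at this place can shift the number in this assay beyond it. An amine, a carboxylic acid or a longer chain on this carbon would test that.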